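The source may hold more compounds than are shown below. What is called first, only, known or untested is meant among the compounds shown, and "the series" means these compounds.

Measured so far:

Compound 1, `O=C1/C(=C/c2ccc(Cl)cc2Cl)CCCc2ccccc21`, in a functional assay on L1210 cells (Mus musculus) for inhibition (on this read-out lower numbers stand for stronger inhibition and higher numbers for weaker inhibition), gives > 500000 nM; this is a limit of the assay and not a number.

Compound 2, `O=C1/C(=C/c2ccccc2Br)CCCc2ccccc21`, in this assay gives 37000 nM.

Among the compounds with values here, compound 2 thus holds the only real number among the values shown, and it stands alone there. Within the data shown here, the other value belongs to compound 1 and sits at the limit of > 500000 nM in this assay, at which 1 of the 2 values shown sits, so no step between the two can be sized, and nothing can be said about how much they differ.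

Compound 3, `O=C1/C(=C/c2ccccc2Cl)CCCc2ccccc21`, differs from compound 2 in a single place: chloro in place of bromo on an aromatic carbon. Among the measured compounds shown here, no measured pair in this set shows the same kind of exchange, so the size of the step has to be guessed from the nature of the change alone. One halogen replaces another at the same place, which is the kind of change that usually moves a value little. For compound 3 the step expected in this assay is a 1.5-fold higher number from compound 2 to compound 3 (0.17 log units; within the scatter), at the edge of the usual scatter and, if anything, toward weaker inhibition. Compound 3 is therefore estimated at 55000 nM, with a range from 18000 nM to 170000 nM.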

Compound 3, half-maximal inhibitory concentration: 42300 nM
Beside the measured number, compound 3's estimate is 1.3-fold (0.11 log units) above it, within the range that was stated.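

In this assay, chloro in place of bromo on the aromatic carbon ortho to a large group gives a 1.1-fold higher number from compound 2 to compound 3 (0.06 log units; within the scatter), so at this place the two halogens cannot be told apart. The same compound also links the series to its inactive end, since losing the further chloro that compound 1 carries, with hydrogen taking its place, gives an at least 11-fold lower number from compound 1 to compound 3 (1.07 log units; beyond the scatter), which means that one extra halogen on the same ring can matter far more than the choice between bromo and chloro. Compound 1 gives > 500000 nM, which is a limit and not a number, so the true size of that step stays unknown because of this entry: the limit of > 500000 nM in this assay, at which 1 of the 3 values shown sits.

What the compounds shown leave open is whether this ortho place needs a halogen at all, as neither hydrogen nor a group of another kind, such as methyl, methoxy or an amine, stands there in any of them. They also leave open whether the further chloro would have the same large effect on another carbon of the ring, or whether a further bromo or fluoro would act as it does.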